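Replacing fluoro with nitro in compound 2

The source may report more compounds than this note shows. Statements on the series, on what has been measured and on what is new or still open speak of the compounds shown alone.

Measured so far in a functional assay on HeLa cells (Homo sapiens) for inhibition, read by CCK-8 assay, with a stated time of 48 h; on this read-out higher numbers stand for weaker inhibition and lower numbers for stronger inhibition:
- compound 1 (`COc1cc(-c2ccnc3cc(-c4ccc(N(C)C)cc4)nn23)cc(OC)c1OC`) gives 378 nM
- compound 2 (`COc1ccc(-c2cc3nccc(-c4cc(OC)c(OC)c(OC)c4)n3n2)cc1F`) gives 236 nM

Going by the values given here, with only two compounds measured, compound 2 can be placed only against compound 1. The comparison is a 1.6-fold lower number from compound 1 to compound 2 (0.20 log units; within the scatter) and so compound 2 sits level with compound 1 on these numbers.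

The next compound is compound 3 (`COc1ccc(-c2cc3nccc(-c4cc(OC)c(OC)c(OC)c4)n3n2)cc1[N+](=O)[O-]`). It has nitro in place of fluoro on an aromatic carbon, ortho to a methoxy group and meta to a large group (nitro in place of fluoro on an aromatic carbon). Among the compounds with values here, the only guide is a 1.6-fold lower number from compound 1 to compound 2 (0.20 log units; within the scatter) and that step altered the same phenyl group that carries the new change. Within the data shown here, it is a different swap, however, and no nitro compound has been measured, so the guide is weak and the range must stay wide. On this evidence, no change beyond the scatter is expected in this assay and the expected step is a 1.3-fold higher number from compound 2 to compound 3 (0.10 log units; within the scatter) in size. Compound 3 is estimated at 300 nM with an expected range from 90 nM to 1000 nM as the likely span.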

Compound 3, half-maximal inhibitory concentration: > 10000 nM
Compound 3 ended at the assay's limit; the forecaster's own chance of this, stated with the estimate: 3%; at least 33-fold (1.52 log units) between middle value and limit.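

In this assay, the earlier step exchanged the whole substituted phenyl group and gave a 1.6-fold lower number from compound 1 to compound 2 (0.20 log units; within the scatter), so those two compounds showed no sensitivity to that change. The swap of fluoro for nitro, a change in one place only, gives an at least 42-fold higher number from compound 2 to compound 3 (1.62 log units; beyond the scatter), which shows that what sits on this aromatic carbon, ortho to a methoxy group, can matter far more than the earlier step indicated. Compound 3 gives > 10000 nM, which is a limit of the assay and not a number: the limit of > 10000 nM in this assay, at which 1 of the 3 values shown sits.

The compounds shown leave open whether this loss belongs to nitro alone or would also appear with other groups on the same carbon. A primary amine or a nitrile at this position, compared directly with compound 2, could help separate these possibilities, and either result would show how narrow the range of groups accepted here really is.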